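A few compounds are considered here, and "the series" means these few. Any claim that something is new, unique, unknown or untested is made for them only; others in the source may bear on it.

Compound 1 `Clc1ccc(-c2csc(N/N=C/c3cccs3)n2)cc1` and compound 2 `Fc1ccc(-c2csc(N/N=C/c3ccc(Cl)cc3Cl)n2)cc1` share one core and differ only in their outer rings. In a functional assay, read by spectrophotometry, with a stated time of 15 min, tested at 80 ug/mL (a higher number here means a stronger effect of the compound at the concentration tested, a lower number a weaker effect), compound 1 gives 96.6%, and compound 2 gives 95.5%. Of these two values, that of compound 2 is the smaller by an amount within the scatter, so the two compounds cannot be told apart. Compound 3 `Clc1ccc(-c2csc(N/N=C/c3ccc(Cl)cc3Cl)n2)cc1` differs from compound 2 by chloro in place of fluoro on an aromatic carbon. Among the compounds with values here, no measured pair shows this change, so only a step within the scatter is expected here, in no set direction. For compound 3 an inhibition of 95% is estimated, from 87% to 99%. The expected step of a number 0.5 percentage points lower from compound 2 to compound 3 (within the scatter) is small.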

Compound 3, a percentage reported as inhibition, at one concentration (the size of the read-out at that concentration, not a potency): 92.3%
Compound 3: the middle estimate sits 2.7 percentage points above what was measured, within the range that was stated.
By their numbers in this assay, from the lowest: compounds 3, 2 and 1 (each within the scatter of the next).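

In this assay the change from 4-fluorophenyl to 4-chlorophenyl gives a number 3.2 percentage points lower from compound 2 to compound 3 (within the scatter), so at this position, para to a large group, chloro and fluoro cannot be told apart. This is a read-out at one concentration, not a potency, so it says only that the size of the effect there stays within the scatter. Nothing measured here links the result to a property of either group.

Going by these compounds, whether this position would tolerate an amine or a carboxylic acid remains open. So does the effect of a longer chain there.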